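This account rests on a few compounds, and the source may have more. Where it says the series, first, only, none or still open, it means among the compounds named here.

Measured so far in a functional assay on the whole organism for antagonist activity, with Mus musculus as the target; a higher number here means that more compound is needed for the effect, a lower number that less compound is needed:
Compound 1 `CC(=O)N(C)CC#CCn1ccnc1`: > 100 mg/kg
Compound 2 `COC(=O)N(C)CC#CCn1ccnc1`: > 100 mg/kg
Compound 3 `CCOC(=O)N(C)CC#CCN1CCCC1`: > 100 mg/kg

Each entry is a limit of the assay and not a number, so the evidence is the limit of > 100 mg/kg in this assay, at which 3 of the 3 values shown sit.

Compound 3 stands at > 100 mg/kg, which is a limit.

Compound 4 `CCOC(=O)N(C)CC#CCn1ccnc1` differs from compound 3 in one place: 1H-imidazol-1-yl in place of pyrrolidin-1-yl on a saturated chain carbon bound to a triple-bonded carbon. Among the compounds with values here, no measured step covers this exchange. Within the data shown here, the only step available, a step that the two limits leave unreadable from compound 1 to compound 2, concerns methoxy in place of methyl on a carbonyl carbon, and it has no readable size.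

More relevant is that compound 1 and compound 2 already carry 1H-imidazol-1-yl. Compound 2, with that group, shows only the limit > 100 mg/kg.

No step beyond the scatter is therefore expected in this assay, and limits alone give no direction. The estimated step is a step that the limit leaves unreadable from compound 3 to compound 4.

For compound 4 the expected value is 120 mg/kg, with an estimated range from 50 mg/kg to 300 mg/kg.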

Compound 4, dose for half-maximal effect: > 100 mg/kg
Compound 4 gave a limit, no number (the forecaster's own chance of this, stated with the estimate: 75%); the middle value is on the limit's open side.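

In this assay compound 4 gives > 100 mg/kg, which is a limit and not a number. Its steps from compound 1, compound 2 and compound 3 therefore cannot be read, because the evidence is only this: the limit of > 100 mg/kg in this assay, at which 4 of the 4 values shown sit. The compounds shown leave open what dose any of them needs for the effect, and whether exchanging pyrrolidin-1-yl for 1H-imidazol-1-yl changes it.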